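A few compounds are considered here, and "the series" means these few. Any claim that something is new, unique, unknown or untested is made for them only; others in the source may bear on it.

The series rests on a shared core, carried by compound 1 `Cc1ccc2nc(Cl)c(/C=N/n3cc(-c4ccc(Br)cc4)nc3N)cc2c1` and compound 2 `Cc1ccc2nc(Cl)c(/C=N/n3cc(-c4ccc5ccccc5c4)nc3N)cc2c1`. In a functional assay on MDA-MB-231 cells (Homo sapiens) for cytotoxicity, read by MTT assay, with a stated time of 48 h (on this read-out lower numbers stand for stronger inhibition and higher numbers for weaker inhibition), compound 1 gives 38200 nM, and in the same assay compound 2 gives 35600 nM. Within the data shown here, the single step between them, a 1.1-fold lower number from compound 1 to compound 2 (0.03 log units; within the scatter), is too small to separate the two, so compound 2 stands level with compound 1 rather than apart from it, and with only two numbers in hand no ordering of this pair can be read.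

Compound 3 `Cc1ccc2nc(Cl)c(/C=N/n3cc(-c4cccs4)nc3N)cc2c1` is the next member. It differs from compound 2 in one place: thiophen-2-yl in place of naphthalen-2-yl on an aromatic carbon. Among the measured compounds shown here, the only measured step that bears on this change is the exchange of one aryl group for another at the same ring carbon, a 1.1-fold lower number from compound 1 to compound 2 (0.03 log units; within the scatter), which left the number where it was. That step gives no ground for expecting a sizeable change of this assay upon a further aryl exchange, though the thiophen-2-yl group is the smallest of the three. On this basis the expected step is a 1.1-fold higher number from compound 2 to compound 3 (0.05 log units; within the scatter), nothing beyond the scatter. Compound 3 is therefore estimated at 40000 nM, with a range from 15000 nM to 110000 nM.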

Compound 3, half-maximal inhibitory concentration: > 50000 nM
Compound 3 gave a limit, no number; the forecaster's own chance of this, stated with the estimate: 15%; middle value at least 1.2-fold (0.09 log units) away from the limit.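

In this assay compound 3 returns a limit of the assay and no number: the limit of > 50000 nM in this assay, at which 1 of the 3 values shown sits.

Set against the two earlier aryl groups on the same aromatic carbon, the change reads as an at least 1.4-fold higher number from compound 2 to compound 3 (0.14 log units; that floor lies within the scatter) and as an at least 1.3-fold higher number from compound 1 to compound 3 (0.11 log units; that floor lies within the scatter); both are floors only, so neither separates compound 3 from the earlier compounds, and neither says how large the true step is. What the earlier pair did not show is how this carbon of the five-membered ring behaves with a five-membered aromatic ring carrying a sulfur atom in place of a group built on six-membered aromatic rings of carbon only, and here, unlike in the exchange of 4-bromophenyl for naphthalen-2-yl, the result is no longer a measured number.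

The compounds shown leave open where the true value of compound 3 lies, so its order against compound 1 and compound 2 stays unsettled. They also leave open what a plain phenyl, a furan-2-yl or a pyridin-2-yl group would give on this same carbon, and so whether the sulfur atom or the smaller ring goes with this result.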